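A few compounds are considered here, and "the series" means these few. Any claim that something is new, unique, unknown or untested is made for them only; others in the source may bear on it.

In a functional assay on T-24 cells (Homo sapiens) for cytotoxicity, read by neutral red uptake, with a stated time of 72 h (a higher number here means a weaker inhibitor, a lower number a stronger inhibitor), compound 1 `CCCCCNc1nc(SCC)nc2ncccc12` gives 4300 nM. Compound 2 `CCCCNc1nc(SC(C)C)nc2ncccc12` gives 12300 nM in this assay, the higher of the two numbers and beyond the scatter from compound 1. Compound 3 `CCCCCNc1nc(SC(C)C)nc2ncccc12` differs from compound 2 by methyl in place of hydrogen on a saturated chain carbon, four bonds along the chain from a nitrogen on an aromatic ring; the rest of the molecule is unchanged. Going by the values given here, no measured pair isolates this chain lengthening on the shared core, so in this assay the step is expected to be small, most likely toward a lower number, though possibly none beyond the scatter. Compound 3 is estimated at 7000 nM, within 2500 nM to 20000 nM. This estimate means an expected step of a 1.8-fold lower number from compound 2 to compound 3 (0.24 log units; within the scatter).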

Compound 3, half-maximal inhibitory concentration: 7900 nM
Compound 3: middle estimate off by 1.1-fold (0.05 log units), on the low side, and the stated range covers the measured number.
By their numbers in this assay, from the lowest: compounds 1, 3 and 2 (each within the scatter of the next, the first and the last beyond it).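

In this assay, methyl in place of hydrogen on a saturated chain carbon, four bonds along the chain from a nitrogen on an aromatic ring, gives a 1.6-fold lower number from compound 2 to compound 3 (0.19 log units; within the scatter). Methyl in place of hydrogen on a saturated chain carbon bound to a saturated chain carbon and a sulfur gives a 1.8-fold higher number from compound 1 to compound 3 (0.26 log units; within the scatter), so compound 3 separates the two changes that lie together between compound 1 and compound 2, and neither alone moves the number beyond the scatter. No supporting data bear on either step.

Open: whether a longer chain at the first position, or an amine at its end, would give a step beyond the scatter.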